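The source may hold more compounds than are shown below. What is called first, only, known or untested is meant among the compounds shown, and "the series" means these compounds.

Measured so far:

- Compound 1, `Nc1ccn([C@H]2CC(F)(F)[C@H](CO)O2)c(=O)n1`: > 100000 nM
- Compound 2, `Nc1nc(=O)n([C@H]2CC(F)(F)[C@H](CO)O2)cc1F`: > 100000 nM
- Compound 3, `Nc1ccn([C@@H]2C=C(F)[C@H](CO)O2)c(=O)n1`: > 100000 nM

The read-out is a functional assay on Vero cells (Chlorocebus sabaeus) for cytotoxicity; on this read-out lower numbers stand for stronger inhibition and higher numbers for weaker inhibition. For compound 1 the reported value is a limit of the assay, not a number. For compound 2 it is likewise a limit. For compound 3 it is also a limit. Compound 2 comes from compound 1 by fluoro in place of hydrogen on an aromatic carbon, and the step that the two limits leave unreadable from compound 1 to compound 2 is one that the two limits leave unreadable.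

Compound 4, `Nc1nc(=O)n([C@@H]2C=C(F)[C@H](CO)O2)cc1F`, has not yet been measured. It comes from compound 3 by fluoro in place of hydrogen on an aromatic carbon. Within the data shown here, this is the same kind of change as the one from compound 1 to compound 2: the places differ only in that the carbon is meta to a group of 8 heavy atoms in compound 3 but to a group of 9 heavy atoms in compound 1. The difference between the two cores is not broken down here.

For compound 4 the step that the limit leaves unreadable from compound 3 to compound 4 is expected to be very small, resting on (the limit of > 100000 nM in this assay, at which 3 of the 3 values shown sit), where all measured values sit. Compound 4 is therefore estimated to give 150000 nM, between 50000 nM and 600000 nM, most likely as a limit again.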

Compound 4, half-maximal inhibitory concentration: > 100000 nM
Compound 4: no number, only a limit (the forecaster's own chance of this, stated with the estimate: 85%); the middle value does not contradict the limit.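

In this assay compound 4 gives > 100000 nM as a limit of the assay, not a number. Among these compounds, compound 3 also carries only a limit, so no step from compound 3 to compound 4 can be read. The compounds shown leave open whether fluoro in place of hydrogen on an aromatic carbon changes anything in this assay at all, with every value at one shared limit: the limit of > 100000 nM in this assay, at which 4 of the 4 values shown sit.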